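Adding a Second Chloro to the Amide Aryl Ring

This account rests on a few compounds, and the source may have more. Where it says the series, first, only, none or still open, it means among the compounds named here.

Three amides built on one shared core have been measured in a functional assay on MDA-MB-468 cells (Homo sapiens) for antiproliferative activity, read by MTT assay, with a stated time of 72 h; on this read-out higher numbers stand for weaker inhibition and lower numbers for stronger inhibition. Compound 1 `O=C(Nc1ccc(Cl)c(-c2nnc3c(Cl)cccn23)c1)c1cccnc1` carries a pyridin-3-yl group on its carbonyl carbon; in this assay compound 1 gives only the limit > 100000 nM, not a number. Compound 2 `O=C(Nc1ccc(Cl)c(-c2nnc3c(Cl)cccn23)c1)c1ccc(Cl)cc1` carries a 4-chlorophenyl group instead; in this assay compound 2 likewise reaches only the limit > 100000 nM. The step that the two limits leave unreadable from compound 1 to compound 2 therefore cannot be sized, because both ends sit at the limit of > 100000 nM in this assay, at which 2 of the 3 values shown sit. Among the measured compounds shown here, compound 3 `O=C(Nc1ccc(Cl)c(-c2nnc3c(Cl)cccn23)c1)c1ccc(C(F)(F)F)cc1F` bears a 2-fluoro-4-trifluoromethylphenyl group, and in this assay compound 3 gives 22300 nM, a number rather than a limit; it differs from compound 2 in more than one place, so no single step joins them.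

Compound 4 `O=C(Nc1ccc(Cl)c(-c2nnc3c(Cl)cccn23)c1)c1ccc(Cl)cc1Cl` is the unmeasured neighbour of compound 2. The change is chloro in place of hydrogen on an aromatic carbon. For the measured compounds named here, no measured step covers this exact change. Since compound 2 stands at a limit, its value only sets a floor for the comparison; the number given by compound 3 shows that a substituted phenyl of this kind can yield a measurable figure. A modest gain is expected, with the step of an at least 2.0-fold lower number from compound 2 to compound 4 (0.30 log units; that floor lies within the scatter) uncertain in size. Compound 4 is estimated at 50000 nM, in a range from 12000 nM to 200000 nM.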

Compound 4, half-maximal inhibitory concentration: 21600 nM
The estimate for compound 4 lay 2.3-fold (0.36 log units) above the measured number; the measured number falls inside the stated range.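

In this assay, among the compounds shown here, a chloro group placed ortho to a large group and meta to the existing chloro group turns an unreadable result into a number, and this single added atom gives the first step that can be sized at this position: an at least 4.6-fold lower number from compound 2 to compound 4 (0.66 log units; beyond the scatter). Set against the pyridin-3-yl amide, the 2,4-dichlorophenyl group likewise shows an at least 4.6-fold lower number from compound 1 to compound 4 (0.66 log units; beyond the scatter). Both steps are minimum sizes and the true gains may be larger, while the step between compound 1 and compound 2 cannot be read, because each of these two compounds stops at a limit of the assay and gives no number: the limit of > 100000 nM in this assay, at which 2 of the 4 values shown sit.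

Chloro is the only group seen in place of this hydrogen on the 4-chlorophenyl ring, so it remains open whether a methyl group, a methoxy group or an amine there would give a step of similar size. As far as these compounds go, it also remains open whether this chloro group would give the same gain on a phenyl ring lacking the 4-chloro group, and whether the potency could reach well below the values seen so far.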